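The source may hold more compounds than are shown below. What is called first, only, known or untested is meant among the compounds shown, and "the series" means these compounds.

Measured compounds in a functional assay on ACHN cells (Homo sapiens) for antiproliferative activity; a higher number here means a weaker inhibitor of growth, a lower number a stronger inhibitor of growth:
Compound 1 `COc1cccc(CN2CC=C(CCC(=O)NO)C2=O)c1` gives 4430 nM.
Compound 2 `COc1ccccc1CN1CC=C(CCC(=O)NO)C1=O` gives only a limit of the assay, > 10000 nM.
Compound 3 `COc1ccc(CN2CC=C(CCC(=O)NO)C2=O)cc1` gives 2480 nM.

Compound 3 holds the lower of the two numbers, but compound 1 lies within the usual scatter of it, so no order between the two can be read. Compound 2 stands at the limit of > 10000 nM in this assay, at which 1 of the 3 values shown sits, and nothing more than that can be said of it.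

Compound 4 `O=C(CCC1=CCN(Cc2ccccc2)C1=O)NO` differs from compound 3 by hydrogen in place of methoxy on an aromatic carbon. Within the data shown here, no measured pair shows this change. Since compounds 1 and 3 sit close together in this assay, the expected step of a 1.4-fold higher number from compound 3 to compound 4 (0.15 log units; within the scatter) is small and not beyond the scatter, if anything toward a slightly higher number. Compound 4 is estimated at 3500 nM, within a range from 1200 nM to 10000 nM.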

Compound 4, concentration for 50% growth inhibition: 1080 nM
For compound 4 the middle estimate is 3.2-fold (0.51 log units) above the measured one; the measured number lies below the stated range.
By their numbers in this assay, from the lowest: compound 4; then compounds 3 and 1 (each within the scatter of the next). At a limit, above all of these: compound 2.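

In this assay, hydrogen in place of methoxy on an aromatic carbon gives a lower number in every comparison: a 2.3-fold lower number from compound 3 to compound 4 (0.36 log units; beyond the scatter), a 4.1-fold lower number from compound 1 to compound 4 (0.61 log units; beyond the scatter) and an at least 9.2-fold lower number from compound 2 to compound 4 (0.96 log units; beyond the scatter). The earlier compounds shown here all carried a methoxy, so they could not show that each of them, wherever its methoxy stands, sits higher than the compound with hydrogen. The step from compound 2 is only a bound, since compound 2 is a limit of the assay: the limit of > 10000 nM in this assay, at which 1 of the 4 values shown sits.

As far as these compounds go, whether fluorine, chlorine or a methyl group on that carbon would fall nearer hydrogen or methoxy stays open.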